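Swapping a Nitrile for Two Chlorines on a Sulfonyl Arm

A few compounds are considered here, and "the series" means these few. Any claim that something is new, unique, unknown or untested is made for them only; others in the source may bear on it.

For the measured compounds named here, compound 1 `CC1CCN(c2c(S(=O)(=O)c3ccc(C#N)cc3)cnc3c(F)cccc23)CC1` is one of two compounds measured in an assay on isolated protein for displacement of a labelled ligand from metabotropic glutamate receptor 5 (Homo sapiens), with a stated time of 60 min, tested at 1 uM; on this read-out lower numbers stand for less inhibition and higher numbers for more inhibition at the one concentration tested (going by the name of the read-out). Compound 1 gives 86%, the lowest of the two numbers, while compound 2 `CC1CCN(c2c(S(=O)(=O)c3ccc(F)cc3)cnc3ccc(F)cc23)CC1` gives 87%, a value that lies within the usual scatter of compound 1. Compound 3 `CC1CCN(c2c(S(=O)(=O)c3ccc(Cl)c(Cl)c3)cnc3c(F)cccc23)CC1` has not been measured; compared with compound 1 it carries 3,4-dichlorophenyl in place of 4-cyanophenyl on a sulfonyl sulfur. Going by the values given here, no measured pair shows what this change does, so the expected step of a number 6 percentage points lower from compound 1 to compound 3 (within the scatter) is estimated to be small and to stay within the scatter. Compound 3 is therefore expected to give about 80%, between 55% and 95%.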

Compound 3, a percentage reported as inhibition, at one concentration (the size of the read-out at that concentration, not a potency): 95%
Beside the measured number, compound 3's estimate is 15 percentage points below it; measured number inside the range.
By their numbers in this assay, from the lowest: compounds 1, 2 and 3 (each within the scatter of the next).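

Going from 4-cyanophenyl to 3,4-dichlorophenyl on a sulfonyl sulfur gives a number 9 percentage points higher from compound 1 to compound 3 (within the scatter) in this assay. In this pair, then, the read-out stays within the usual scatter when the nitrile is gone and two chlorines are present, so the nitrile is not required for inhibition at this one concentration. Nothing measured on these groups bears on why the two compounds read alike.

Still open, as far as these compounds go, is whether a carboxylic acid or an amine on this phenyl ring would keep the read-out. A single concentration also leaves open whether compound 1 and compound 3 differ in potency.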